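The source may report more compounds than this note shows. Statements on the series, on what has been measured and on what is new or still open speak of the compounds shown alone.

Three compounds share one core. Compound 1 `NC(=O)Nc1sc(-c2ccc(C(=O)N3CCOCC3)cc2)cc1C(=O)N[C@H]1CCCNC1` belongs to the set, but in an assay on isolated protein for inhibition of cyclin-dependent kinase 2-associated protein 1 (Homo sapiens) (on this read-out lower numbers stand for stronger inhibition and higher numbers for weaker inhibition), compound 1 gives "not determined" (no result reported), so no result is reported for it. For the measured compounds named here, compound 2 `CN(C)C(=O)c1ccc(-c2cc(C(=O)N[C@H]3CCCNC3)c(NC(N)=O)s2)cc1` is the only compound with a number: in this assay compound 2 gives 3700 nM, and it is the sole point of reference here, since no other entry carries a value. Compound 3 `CS(=O)(=O)c1ccc(-c2cc(C(=O)N[C@H]3CCCNC3)c(NC(N)=O)s2)cc1` differs from compound 2 in one place: methylsulfonyl in place of dimethylcarbamoyl on an aromatic carbon, para to a large group. Going by the values given here, no pair of measured compounds shows how such a swap shifts the read-out, so the expectation rests on the single value of compound 2 alone. Without a measured step to lean on, the step is expected to stay within the usual scatter, no change at the digits printed from compound 2 to compound 3 (within the scatter). Compound 3 is estimated at 3700 nM, with a range from 1200 nM to 11000 nM.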

Compound 3, half-maximal inhibitory concentration: 2200 nM
The estimate for compound 3 lay 1.7-fold (0.23 log units) above the measured number, within the range that was stated.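

In this assay, putting methylsulfonyl in place of dimethylcarbamoyl gives a 1.7-fold lower number from compound 2 to compound 3 (0.23 log units; within the scatter). For the compounds shown here, this is the first measured step at this place on the six-membered aromatic ring, para to a large group, and on this read-out the two groups cannot be told apart, even though they differ in their atoms and in their counted hydrogen-bond acceptors. Nothing available here bears on why the swap leaves the number within the scatter.

Compound 1 gives "not determined" (no result reported) in this assay, so any step involving it cannot be read. From the compounds shown here alone, whether an amine or a carboxylic acid at this same place would move the number beyond the scatter remains open, and one swap at one place says nothing about the rest of the shared core.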